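Pyridine to thiazole on the amine nitrogen of compound 2

This account rests on a few compounds, and the source may have more. Where it says the series, first, only, none or still open, it means among the compounds named here.

Compound 2 `Cc1cccc(N/C(S)=N/[C@@H](C)c2cccc3ccccc23)n1` is measured in a functional assay on RBL-2H3 cells (Rattus norvegicus) for inhibition (a lower number here means a stronger inhibitor, a higher number a weaker inhibitor), at 1600 nM. Among the compounds with a number in this assay it stands at the weaker end, the highest of the two values: compound 3 `CCOC(=O)Cc1csc(/N=C(\S)N[C@@H](C)c2cccc3ccccc23)n1` gives 9 nM, a much lower number. Compound 1 `C[C@H](/N=C(\S)Nc1ccccn1)c1cccc2ccccc12` reaches only the limit of the assay, > 100000 nM, so no number is known for it; it sits at the limit of > 100000 nM in this assay, at which 1 of the 3 values shown sits. For the measured compounds named here, the one step measured between neighbours is the change of hydrogen to methyl on an aromatic carbon, and it brought an at least 62-fold lower number from compound 1 to compound 2 (1.79 log units; beyond the scatter).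

Compound 4 `C[C@H](/N=C(\S)Nc1nccs1)c1cccc2ccccc12` differs from compound 2 by 1,3-thiazol-2-yl in place of 6-methylpyridin-2-yl on an amine nitrogen. Going by the values given here, no measured step covers this kind of exchange directly, so it can be read only against what the values show: the only other compound that carries a thiazole ring, compound 3, gives a far lower number than compound 2, while the measured step from compound 1 to compound 2 shows how strongly this assay responds to a change on the aromatic ring. An improvement is therefore expected for compound 4, though a smaller one than the gap to compound 3, estimated as a 5.3-fold lower number from compound 2 to compound 4 (0.73 log units; beyond the scatter). The value expected for compound 4 in this assay is 300 nM, with a range from 30 nM to 5000 nM.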

Compound 4, half-maximal inhibitory concentration: > 100000 nM
Compound 4 ended at the assay's limit; the forecaster's own chance of this, stated with the estimate: 5%; at least 330-fold (2.52 log units) between middle value and limit.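

Exchanging 6-methylpyridin-2-yl for 1,3-thiazol-2-yl on the amine nitrogen gave an at least 62-fold higher number from compound 2 to compound 4 (1.79 log units; beyond the scatter), so in this assay the thiazole ring alone does not account for the low number of compound 3. Compound 3, which carries the same ring with an ethyl ester side chain, gives 9 nM, so among these compounds that low number goes with the ring and its side chain together. The step from compound 1 to compound 4 cannot be read, and the two compounds whose aromatic ring bears no further group are the two that share the assay's limit: the limit of > 100000 nM in this assay, at which 2 of the 4 values shown sit.

What the compounds shown leave open is which part of the ethyl ester side chain matters, and whether a plain methyl group, a carboxylic acid or an amide in its place on the thiazole ring would keep a measurable number in this assay. They also leave open whether an ethyl group or a longer chain in place of the methyl group of compound 2 would lower its number further.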